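Aromatic Ring Returns to the Amide Carbonyl

A few compounds are considered here, and "the series" means these few. Any claim that something is new, unique, unknown or untested is made for them only; others in the source may bear on it.

Among the compounds with values here, compound 2 `COc1cc(/C=C/C(=O)c2cccc(NC(=O)C(C)C)c2)ccc1O` is one of two compounds measured in a functional assay on HUVEC cells (Homo sapiens) for inhibition, tested at 2.5 ug/mL; a lower number here means a weaker effect, a higher number a stronger effect of the compound at the concentration tested. Compound 2 gives 11%, the lower of the two numbers. Compound 1 `COc1cc(/C=C/C(=O)c2cccc(NC(=O)c3ccco3)c2)ccc1O` gives 61%. The two differ only at the carbonyl carbon of the amide: a number 50 percentage points lower from compound 1 to compound 2 (beyond the scatter).

Compound 3 `COc1cc(/C=C/C(=O)c2cccc(NC(=O)c3cc(Cl)cc(Cl)c3)c2)ccc1O` has not been measured. It differs from compound 2 in one place: 3,5-dichlorophenyl in place of isopropyl on a carbonyl carbon. As in compound 1, an aromatic ring thus sits on the carbonyl carbon whose other neighbour is the amide-type nitrogen, whereas compound 2 carries isopropyl there.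

Within the data shown here, the single measured step that bears on this change is the large drop from furan-2-yl to isopropyl. Going back from isopropyl to an aromatic ring would be expected to raise the number, though a dichlorophenyl ring is not a furan ring, so the range is wide. A rise beyond the scatter is expected, a number 39 percentage points higher from compound 2 to compound 3 (beyond the scatter). Compound 3 is estimated at 50%, with a range from 25% to 75%.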

Compound 3, a percentage reported as inhibition, at one concentration (the size of the read-out at that concentration, not a potency): 15%
Compound 3: the middle estimate sits 35 percentage points above what was measured; measured number outside the range, below it.
By their numbers in this assay, from the lowest: compounds 2 and 3 (each within the scatter of the next); then compound 1.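

In this assay, an aromatic ring on this carbonyl carbon does not by itself restore the effect: 3,5-dichlorophenyl in place of isopropyl gives a number 4 percentage points higher from compound 2 to compound 3 (within the scatter) and leaves the two compounds indistinguishable. Replacing furan-2-yl with the same dichlorinated ring gives a number 46 percentage points lower from compound 1 to compound 3 (beyond the scatter) and shows that the two aromatic rings are not interchangeable at this position, so having a ring there does not account for the higher number of compound 1. Nothing available explains why these two rings differ.

From the compounds shown here alone, it remains open whether an unsubstituted phenyl ring or a thiophene ring would read like furan-2-yl or like 3,5-dichlorophenyl. Going by these compounds, it is also open whether the two chlorine atoms matter, which a comparison with phenyl or with a single chlorine atom on the ring could begin to address.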